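The source may hold more compounds than are shown below. What is called first, only, known or untested is meant among the compounds shown, and "the series" means these compounds.

Three compounds share a common core and were examined for inhibition of the flavin-containing amine oxidase B. Compound 1 `CCN(CCCCn1sc2cc(OC)c(OC)cc2c1=O)Cc1ccccc1` was tested in an assay on isolated protein for inhibition of Amine oxidase [flavin-containing] B (Homo sapiens), read by fluorescence, with a stated time of 30 min (on this read-out lower numbers stand for stronger inhibition and higher numbers for weaker inhibition), where compound 1 gives 20100 nM. Compound 2 `CCN(CCCCn1sc2cc(OC)c(OC)cc2c1=O)Cc1ccccc1OC` differs from it by methoxy in place of hydrogen on an aromatic carbon, and in this assay compound 2 gives 19400 nM; this amounts to a 1.0-fold lower number from compound 1 to compound 2 (0.02 log units; within the scatter). Compound 3 `COc1cc2sn(CCCCCCN(C)Cc3ccccc3)c(=O)c2cc1OC` carries a differently built core, and the difference between the two cores is not broken down here. In this assay compound 3 gives 13200 nM, a value that lies within the scatter of the other two, so no order among the three can be stated.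

Compound 4 `COc1ccccc1CN(C)CCCCCCn1sc2cc(OC)c(OC)cc2c1=O` has not yet been measured. It differs from compound 3 by methoxy in place of hydrogen on an aromatic carbon, the same change, at the same kind of place, as that seen between compound 1 and compound 2. Because the earlier step of a 1.0-fold lower number from compound 1 to compound 2 (0.02 log units; within the scatter) stayed within the scatter, the step from compound 3 to compound 4 is expected to be a 1.1-fold lower number from compound 3 to compound 4 (0.02 log units; within the scatter). Compound 4 is therefore estimated to give 12500 nM in this assay, with a likely range from 6000 nM to 26000 nM.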

Compound 4, half-maximal inhibitory concentration: 13700 nM
Estimate against measurement, compound 4: 1.1-fold (0.04 log units) below, and the stated range covers the measured number.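

In this assay, the change from benzyl to 2-methoxybenzyl gives a 1.0-fold higher number from compound 3 to compound 4 (0.02 log units; within the scatter), so this step, like the earlier one, shows no measurable effect. Set side by side, the two steps do not differ between the two cores: the same change on two cores in this assay, a 1.0-fold lower number (0.02 log units; within the scatter) from compound 1 to compound 2 and a 1.0-fold higher number (0.02 log units; within the scatter) from compound 3 to compound 4, 1.1-fold (0.03 log units) apart, within the scatter of two such steps. This shows that in this assay the methoxy change is equally silent on both cores, but it does not show that an effect of any size carries from one core to another, as neither step rises above the scatter, and two cores cannot establish a rule for the whole series.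

The compounds shown leave open whether a different group on this aromatic ring, such as chlorine or a nitrile, would produce a readable step on either core. They also leave open how an amide in place of the amine, or a longer chain, would read in this assay.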